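Chloro to trifluoromethyl on the anilino ring

The source may report more compounds than this note shows. Statements on the series, on what has been measured and on what is new or still open speak of the compounds shown alone.

Measured so far:
Compound 1 `CC(C)c1ccc(-c2nc(SCc3cn(CC(=O)NC(=O)Nc4ccccn4)nn3)nc(Nc3cccc(C(F)(F)F)c3)c2C#N)cc1` in a functional assay on MGC-803 cells (Homo sapiens) for inhibition, read by MTT assay, with a stated time of 72 h (a higher number here means a weaker inhibitor, a lower number a stronger inhibitor), gives > 64000 nM, which is a limit of the assay and not a number.
Compound 2 `Cc1ccc(-c2nc(SCc3cn(CC(=O)NC(=O)Nc4ccccn4)nn3)nc(Nc3cccc(Cl)c3)c2C#N)cc1` in this assay gives 7890 nM.

Among the compounds with values here, compound 2 holds the only real number in this assay; the other value shown for this series is a limit, as the note the limit of > 64000 nM in this assay, at which 1 of the 2 values shown sits, records. Compound 3 `Cc1ccc(-c2nc(SCc3cn(CC(=O)NC(=O)Nc4ccccn4)nn3)nc(Nc3cccc(C(F)(F)F)c3)c2C#N)cc1` has not been measured. It differs from compound 2 in one place: trifluoromethyl in place of chloro on an aromatic carbon. Within the data shown here, no pair of measured compounds differing in only this way exists, so the size of this step is not known from the data. Among the measured compounds shown here, the one other compound with a trifluoromethyl on that ring, compound 1, gave only a limit, which gives no direction on its own but leaves open that potency may fall. The step from compound 2 to compound 3 is therefore expected to go toward weaker inhibition, by a 2.5-fold higher number from compound 2 to compound 3 (0.40 log units; beyond the scatter), with much uncertainty. Compound 3 is estimated at 20000 nM, within a range from 6000 nM to 64000 nM.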

Compound 3, half-maximal inhibitory concentration: 7580 nM
Compound 3: middle estimate off by 2.6-fold (0.42 log units), on the high side; the range from low to high includes it.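

In this assay, a 1.0-fold lower number from compound 2 to compound 3 (0.02 log units; within the scatter), which lies within the scatter, so at this position a trifluoromethyl of four heavy atoms reads the same as a chloro of one heavy atom. Within the data shown here, the trifluoromethyl therefore cannot by itself be held responsible for the poor reading of compound 1, since compound 3 carries the same group; the one place in which compound 1 and compound 3 differ is methyl in place of isopropyl on an aromatic carbon, and an at least 8.4-fold lower number from compound 1 to compound 3 (0.92 log units; beyond the scatter), a step beyond the scatter. The value of compound 1 is a limit of the assay and not a number, so this step has no exact size: the limit of > 64000 nM in this assay, at which 1 of the 3 values shown sits.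

The compounds shown place only chloro and trifluoromethyl at the anilino position, so it remains open whether an amine or a carboxylic acid there would read any differently from these two. On these data alone, it also remains open how an ethyl, or a plain hydrogen, would read on the aromatic carbon that carries the methyl in compound 3.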